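Series notes: the step from compound 2 to compound 4

The source may report more compounds than this note shows. Statements on the series, on what has been measured and on what is new or still open speak of the compounds shown alone.

Measured so far in a physicochemical assay for lipophilicity, at pH 7.4; a higher number here means a more lipophilic compound, a lower number a more polar compound
compound 1 (`Cc1cc(C)c(CN2CCc3c(Cl)cc(C(CO)c4ccon4)c(Cl)c3C2=O)c(=O)[nH]1`) with 2; 2 (2 entries)
compound 2 (`Cc1cc(C)c(CN2CCc3c(Cl)cc([C@@H](CO)[C@@H]4CCOC4)c(Cl)c3C2=O)c(=O)[nH]1`) with 2
compound 3 (`Cc1cc(C)c(CN2CCc3c(Cl)cc(C(CO)C4CCOC4)c(Cl)c3C2=O)c(=O)[nH]1`) with 2.1; 2.1 (2 entries)

Compound 2 gives 2 as a single reading, while the other two entries hold repeat readings. All three compounds lie within the usual scatter of one another. Between compound 2 and compound 3 there stands only the fact that one of compounds 2 and 3 is drawn with a defined configuration and the other without, at the place where they differ and their values show no gap beyond that scatter.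

The next compound is a larger departure. Compound 4 (`Cc1cc(C)c(CN2CCc3c(Cl)cc(-c4c(C)noc4C)c(Cl)c3C2=O)c(=O)[nH]1`) differs from compound 2 by a group of 7 heavy atoms (5 carbon, 1 nitrogen, 1 oxygen; one five-membered aromatic ring with 2 hetero atoms) in place of a group of 8 heavy atoms (6 carbon, 2 oxygen; one five-membered non-aromatic ring with 1 hetero atom), on an aromatic carbon and carries 3,5-dimethyl-1,2-oxazol-4-yl on an aromatic carbon, ortho to a chloro group. Among the measured compounds shown here, no measured step covers this kind of change. The expectation therefore starts from compound 2 at 2 and remains an estimate with a wide margin.

The estimated step of a number 1.00 log units higher from compound 2 to compound 4 (beyond the scatter) is expected to be upward and beyond the usual scatter in this assay. The expected value for compound 4 is 3 with an estimated range from 2.5 to 3.5 for the coming measurement.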

Compound 4, distribution coefficient: 3.1
Estimate against measurement, compound 4: 0.10 log units below; low and high end bracket the measured number.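

In this assay this position, an aromatic carbon ortho to a chloro group, proves able to carry a change well beyond the scatter: putting 3,5-dimethyl-1,2-oxazol-4-yl in place of the group of 8 heavy atoms gives a number 1.10 log units higher from compound 2 to compound 4 (beyond the scatter), whereas the compounds before it showed no gap beyond that scatter. Several features change together in this one step, as a five-membered non-aromatic ring with 1 hetero atom, 1 hydrogen-bond donor and 2 defined stereocentres gives way to a five-membered aromatic ring with 2 hetero atoms and 0 hydrogen-bond donors, and the size of the step cannot be divided among these features. Nothing measured here bears on why the step has this size, and the difference in drawn configuration between compound 2 and compound 3 does not speak to it.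

The compounds shown do not separate the contribution of the aromatic ring from that of its two methyl groups in 3,5-dimethyl-1,2-oxazol-4-yl. From the compounds shown here alone, how an amine, a carboxylic acid or a longer chain on this aromatic carbon would read in this assay also remains open.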